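The compounds below may be only part of what the source reports. "The series", "measured", "known", "first", "only" and "open" are said of these compounds alone.

Measured in an ADME assay on HepG2 cells (Homo sapiens) for cytotoxicity; a higher number here means that more compound is tolerated, a lower number that less compound is tolerated
- Compound 1 `CCOC(=O)CN(C)CC#Cc1cc2ncnc(Nc3ccc(OCc4cccc(F)c4)c(Cl)c3)c2s1` gives 26 uM
- Compound 2 `COCC#Cc1cc2ncnc(Nc3ccc(OCc4cccc(F)c4)c(Cl)c3)c2s1` gives > 33 uM

Compound 2 stands only at a limit, not at a number (the limit of > 33 uM in this assay, at which 1 of the 2 values shown sits). Compound 3 `Fc1cccc(COc2ccc(Nc3ncnc4cc(C#CC5CCCC5)sc34)cc2Cl)c1` differs from compound 2 by cyclopentyl in place of methoxymethyl on a triple-bonded carbon, with cyclopentyl in place of methoxymethyl on a triple-bonded carbon. Among the compounds with values here, the one measured step that bears on this swaps a different pair of groups and is small (an at least 1.2-fold higher number from compound 1 to compound 2 (0.10 log units; that floor lies within the scatter)). No step beyond the scatter is therefore expected in this assay. The expected change is an at least 1.1-fold lower number from compound 2 to compound 3 (0.07 log units; that floor lies within the scatter). Compound 3 is estimated at 28 uM (expected range 13 uM to 45 uM).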

Compound 3, half-maximal toxic concentration: > 31 uM
Compound 3: only a limit was reported; the forecaster's own chance of this, stated with the estimate: 50%; middle value at least 1.1-fold (0.04 log units) away from the limit.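

In this assay, compound 3, with cyclopentyl on a triple-bonded carbon, gives > 31 uM, which is a limit of the assay, so a five-membered ring of carbon only at this place also ends at a limit, as methoxymethyl did in compound 2. Against the longer amino ester chain, the change gives an at least 1.1-fold higher number from compound 1 to compound 3 (0.07 log units; that floor lies within the scatter). The step between compound 2 and compound 3 cannot be read because both values are limits: the limit of > 31 uM in this assay, at which 1 of the 3 values shown sits.

On these data alone, how far either compound lies past its limit stays open. Also open, as far as these compounds go, is how a carboxylic acid or a primary amine at this place would read.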